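Chain extension on an aromatic nitrogen of the shared core

The source may hold more compounds than are shown below. What is called first, only, known or untested is meant among the compounds shown, and "the series" means these compounds.

The measured compounds in a functional assay on KB cells (Homo sapiens) for antiproliferative activity, read by MTT assay, with a stated time of 48 h; a higher number here means a weaker inhibitor, a lower number a stronger inhibitor:
Compound 1, `Cn1cc(C2=C(c3n[nH]c4ncccc34)C(=O)NC2=O)c2ccccc21`, gives 62000 nM.
Compound 2, `Cn1cc(C2=C(c3nn(CCn4ccnc4)c4ncccc34)C(=O)NC2=O)c2ccccc21`, gives only a limit of the assay, > 100000 nM.
Compound 3, `CN(C)CCCn1nc(C2=C(c3cn(C)c4ccccc34)C(=O)NC2=O)c2cccnc21`, likewise gives only a limit, > 100000 nM.

Compound 3 therefore stands not at a number but at a limit, and the same holds for compound 2, as the limit of > 100000 nM in this assay, at which 2 of the 3 values shown sit, records. Against compound 1 the steps are an at least 1.6-fold higher number from compound 1 to compound 2 (0.20 log units; that floor lies within the scatter) and an at least 1.6-fold higher number from compound 1 to compound 3 (0.20 log units; that floor lies within the scatter), both floors within the scatter. Between the two limit compounds the step is a step that the two limits leave unreadable from compound 2 to compound 3.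

Compound 4, `Cn1cc(C2=C(c3nn(CCCCn4ccnc4)c4ncccc34)C(=O)NC2=O)c2ccccc21`, differs from compound 3 by (1H-imidazol-1-yl)methyl in place of dimethylamino on a saturated chain carbon, three bonds along the chain from an aromatic nitrogen. Going by the values given here, the one measured step of the same kind, a step that the two limits leave unreadable from compound 2 to compound 3, gives no readable size, and compound 2, which also carries an imidazolyl chain on that aromatic nitrogen, sits at the limit. Compound 4 is therefore expected to remain at or near the limit, and the expected step is a number no higher from compound 3 to compound 4 (the limit leaves the size open). The estimate for compound 4 in this assay is 100000 nM, within 40000 nM to 300000 nM.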

Compound 4, half-maximal inhibitory concentration: > 100000 nM
Compound 4: no number, only a limit (the forecaster's own chance of this, stated with the estimate: 80%); the middle value sits exactly at the limit.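

In this assay, the 4-(1H-imidazol-1-yl)butyl chain on this aromatic nitrogen leaves compound 4 at a limit and not at a number, just as the shorter 2-(1H-imidazol-1-yl)ethyl chain left compound 2, so the longer imidazolyl chain yields no readable value. Going by these compounds alone, the only readable step is an at least 1.6-fold higher number from compound 1 to compound 4 (0.20 log units; that floor lies within the scatter), and the steps among the compounds at the limit cannot be read. With compound 4, the limit now holds most of the series: the limit of > 100000 nM in this assay, at which 3 of the 4 values shown sit.

As far as these compounds go, how far compound 2, compound 3 and compound 4 lie beyond that limit remains open, so the three chains cannot be ranked. Also open, from the compounds shown here alone, is whether a small methyl group, a chain ending in morpholine or one ending in a carboxylic acid on this nitrogen would give a number at all.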